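Chlorine Moves In Where Fluorine Stood

The source may report more compounds than this note shows. Statements on the series, on what has been measured and on what is new or still open speak of the compounds shown alone.

Measured so far in a functional assay on HT-29 cells (Homo sapiens) for inhibition, read by sulforhodamine B assay, with a stated time of 48 h; on this read-out higher numbers stand for weaker inhibition of growth and lower numbers for stronger inhibition of growth:
Compound 1, `COc1ccc(/C=N/NC(=S)NC(C)(C)[C@H]2CC=C(C)CC2)cc1`, gives 33600 nM.
Compound 2, `CC1=CC[C@H](C(C)(C)NC(=S)N/N=C/c2ccccc2O)CC1`, gives 16600 nM.
Compound 3, `CC1=CC[C@H](C(C)(C)NC(=S)N/N=C/c2ccc(F)cc2)CC1`, gives only a limit of the assay, > 100000 nM.

Compound 3 thus sits at the weak end of the three, at the limit (the limit of > 100000 nM in this assay, at which 1 of the 3 values shown sits). The step to compound 4, `CC1=CC[C@H](C(C)(C)NC(=S)N/N=C/c2ccccc2Cl)CC1`, is 2-chlorophenyl in place of 4-fluorophenyl on a carbon with a double bond to nitrogen. Two measured steps involve the same aromatic ring: an at least 2.9-fold higher number from compound 1 to compound 3 (0.47 log units; beyond the scatter) and an at least 6.0-fold higher number from compound 2 to compound 3 (0.77 log units; beyond the scatter), both moving towards the limit. Compound 4 carries a different halogen in a different position, so a return towards the range of compound 1 and compound 2 is possible but uncertain. The expected estimate for compound 4 in this assay is 40000 nM, between 10000 nM and 150000 nM, an expected step of an at least 2.5-fold lower number from compound 3 to compound 4 (0.39 log units; beyond the scatter).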

Compound 4, concentration for total growth inhibition: > 100000 nM
Compound 4: no number, only a limit (the forecaster's own chance of this, stated with the estimate: 35%); middle value at least 2.5-fold (0.39 log units) away from the limit.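

In this assay, compound 4 with 2-chlorophenyl gives only a limit of the assay, as compound 3 with 4-fluorophenyl does, so the step between them cannot be read: the limit of > 100000 nM in this assay, at which 2 of the 4 values shown sit.

Chloro in place of hydroxy gives an at least 6.0-fold higher number from compound 2 to compound 4 (0.77 log units; beyond the scatter), and 2-chlorophenyl in place of 4-methoxyphenyl gives an at least 2.9-fold higher number from compound 1 to compound 4 (0.47 log units; beyond the scatter). Among these four compounds, only the rings carrying hydroxy or methoxy give numbers, while both halogen-bearing rings stop at the limit.

Any difference between chloro and fluoro stays hidden there. Going by these compounds, how an amine or a carboxylic acid on this aromatic ring would behave remains open.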